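Swapping the Amine on the Thiocarbonyl Near the Assay Limit

A few compounds are considered here, and "the series" means these few. Any claim that something is new, unique, unknown or untested is made for them only; others in the source may bear on it.

Measured compounds:
Compound 1, `O=c1cc(CSC(=S)N2CCCC2)oc2cc(Cl)ccc12` — > 25000 nM
Compound 2, `CC(C)N(C(=S)SCc1oc2ccccc2c(=O)c1Cl)C(C)C` — 18100 nM
Compound 3, `CC(C)N(C(=S)SCc1cc(=O)c2ccc(Cl)cc2o1)C(C)C` — > 25000 nM

All three compounds were tested in a functional assay on SW480 cells (Homo sapiens) for antiproliferative activity, read by MTT assay, with a stated time of 72 h; on this read-out higher numbers stand for weaker inhibition and lower numbers for stronger inhibition. Compound 1 gives > 25000 nM, which is a limit of the assay and not a number. Compound 3 likewise gives > 25000 nM, again a limit. Among the compounds with values here, compound 2 is the only compound with a measured number, 18100 nM. Compound 2 and compound 3 are built from the same atoms joined differently; the difference between their two cores is not broken down here.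

Compound 3 and compound 1 differ in one place: pyrrolidin-1-yl in place of diisopropylamino on a thiocarbonyl carbon. The step that the two limits leave unreadable from compound 3 to compound 1 cannot be sized, because the limit of > 25000 nM in this assay, at which 2 of the 3 values shown sit, means both ends of that step are limits rather than numbers.

Compound 4, `O=c1c(Cl)c(CSC(=S)N2CCCC2)oc2ccccc12`, has not yet been measured. It differs from compound 2 by the same change: pyrrolidin-1-yl in place of diisopropylamino on a thiocarbonyl carbon. Within the data shown here, the only measured example of this change gives no readable size, so the expectation for compound 4 rests mainly on the starting point, compound 2 at 18100 nM. The expected step is therefore small, a 1.4-fold higher number from compound 2 to compound 4 (0.14 log units; within the scatter), with wide uncertainty. Compound 4 is expected to give about 25000 nM, somewhere between 10000 nM and 60000 nM, with a real chance that the assay reports only a limit for it.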

Compound 4, half-maximal inhibitory concentration: 1400 nM
For compound 4 the middle estimate is 18-fold (1.25 log units) above the measured one; the whole stated range lies above it.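

In this assay, putting pyrrolidin-1-yl in place of diisopropylamino on the core of compound 2 gives a 13-fold lower number from compound 2 to compound 4 (1.11 log units; beyond the scatter), so on this core the swap of one amine for another on the thiocarbonyl carbon has a large effect on the read-out. The same swap on the other core, the step from compound 3 to compound 1, cannot be read, because both compounds stand at a limit and not at a number: the limit of > 25000 nM in this assay, at which 2 of the 4 values shown sit. This means the series offers one sized example of the change, which shows that it can matter a great deal on one core, but it neither confirms nor rules out a step of similar size on the core of compound 3, so no rule for carrying the change between cores follows from it.

As far as these compounds go, it remains open whether the lower number belongs to pyrrolidin-1-yl in particular, or whether another amine on the thiocarbonyl carbon, such as piperidin-1-yl, morpholin-4-yl or diethylamino, would give a similar result on the core of compound 4. It also remains open why the same change might behave differently on the two cores, since nothing shown here speaks to a cause.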